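The source may report more compounds than this note shows. Statements on the series, on what has been measured and on what is new or still open speak of the compounds shown alone.

Measured compounds:
Compound 1, `CCCNc1nc(SC)nc2ncccc12`, 270 nM.
Compound 2, `CCCCNc1nc(SC)nc2ncccc12`, 270 nM.
Compound 3, `COc1ccc(Nc2nc(SC)nc3ncccc23)cc1`, 9420 nM.

These values come from a functional assay (Nicotiana tabacum); on this read-out higher numbers stand for weaker inhibition and lower numbers for stronger inhibition. The change from compound 1 to compound 2, (methyl in place of hydrogen on a saturated chain carbon, three bonds along the chain from a nitrogen on an aromatic ring), gave no change at the digits printed from compound 1 to compound 2 (within the scatter). Compound 3 differs from compound 1 in more than one place, so the difference between the two cores is not broken down here; compound 3 simply gives the highest of the three numbers.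

Compound 4, `CCOc1ccc(Nc2nc(SC)nc3ncccc23)cc1`, is not yet measured. It differs from compound 3 by methyl in place of hydrogen on a saturated chain carbon bound to an oxygen on an aromatic ring, the same kind of change as that from compound 1 to compound 2, though there the place was a saturated chain carbon three bonds along the chain from a nitrogen on an aromatic ring, here a saturated chain carbon bound to an oxygen on an aromatic ring. Because no change at the digits printed from compound 1 to compound 2 (within the scatter), a similarly small step, a 1.1-fold lower number from compound 3 to compound 4 (0.04 log units; within the scatter), is expected here. Compound 4 is therefore estimated at 8500 nM, roughly between 3000 nM and 25000 nM.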

Compound 4, half-maximal inhibitory concentration: 5420 nM
Beside the measured number, compound 4's estimate is 1.6-fold (0.20 log units) above it; the range from low to high includes it.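

In this assay the change from methoxy to ethoxy gave a 1.7-fold lower number from compound 3 to compound 4 (0.24 log units; within the scatter) and so counts as a small step. Set beside the same methyl addition on the other core, this step does not stand apart: the same change on two cores in this assay, no change at the digits printed (within the scatter) from compound 1 to compound 2 and a 1.7-fold lower number (0.24 log units; within the scatter) from compound 3 to compound 4, 1.7-fold (0.24 log units) apart, within the scatter of two such steps. The small size of this change therefore carried over between these two cores, but two pairs cannot show that it would hold on other cores or in other places.

The compounds shown leave open what a clearly larger change would do, such as a longer chain like hexyl in place of the ethoxy group. They also leave open what an amine or a carboxylic acid would do there.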